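Extending the Aryl Arm with a Methoxyphenyl Ethenyl Group

A few compounds are considered here, and "the series" means these few. Any claim that something is new, unique, unknown or untested is made for them only; others in the source may bear on it.

Three measured compounds share one core and differ only in the group attached to it. Compound 1 `CCCCCCCCS(=O)(=O)Nc1cc(-c2ccccc2OC)ccc1C(=O)O` gives 16100 nM in an assay on mitochondria (strain BALB/c) for inhibition of glycerol-3-phosphate acyltransferase 1, mitochondrial (Mus musculus), read by scintillation counting, with a stated time of 10 min; a higher number here means a weaker inhibitor, a lower number a stronger inhibitor. Compound 2 `CCCCCCCCS(=O)(=O)Nc1cc(-c2ccc(OC)cc2)ccc1C(=O)O` gives 13300 nM in this assay, and compound 3 `CCCCCCCCS(=O)(=O)Nc1cc(-c2cccc(F)c2)ccc1C(=O)O` gives 32600 nM. Compound 3 stands with the highest number of the three: a 2.0-fold higher number from compound 1 to compound 3 (0.31 log units; beyond the scatter) and a 2.5-fold higher number from compound 2 to compound 3 (0.39 log units; beyond the scatter), while a 1.2-fold lower number from compound 1 to compound 2 (0.08 log units; within the scatter) keeps the two methoxy compounds within the scatter of each other. Compound 4 `CCCCCCCCS(=O)(=O)Nc1cc(/C=C/c2ccc(OC)cc2)ccc1C(=O)O` is not yet measured; it differs from compound 3 in that (2-(4-methoxyphenyl)ethenyl in place of 3-fluorophenyl on an aromatic carbon). Among the measured compounds shown here, the step from compound 2 to compound 3 bears on this most directly, since it swapped a 4-methoxyphenyl for the 3-fluorophenyl and raised the number; compound 4 brings a 4-methoxyphenyl back, now held on an ethenyl linker, for which no measured step exists. A modest fall in this assay is expected for compound 4, about a 2.5-fold lower number from compound 3 to compound 4 (0.40 log units; beyond the scatter). Compound 4 is estimated at 13000 nM, with a range from 4000 nM to 40000 nM.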

Compound 4, half-maximal inhibitory concentration: 38700 nM
Estimate against measurement, compound 4: 3.0-fold (0.47 log units) below, and the stated range covers the measured number.
By their numbers in this assay, from the lowest: compounds 2 and 1 (each within the scatter of the next); then compounds 3 and 4 (each within the scatter of the next).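

Lengthening the arm with an ethenyl linker does not hold the number at the level of the directly attached methoxyphenyl groups, as both steps lie beyond the scatter (a 2.9-fold higher number from compound 2 to compound 4 (0.46 log units; beyond the scatter)) (a 2.4-fold higher number from compound 1 to compound 4 (0.38 log units; beyond the scatter)). Against the 3-fluorophenyl group, the 2-(4-methoxyphenyl)ethenyl group, with more heavy atoms and a hydrogen-bond acceptor, shows no change beyond the scatter in this assay (a 1.2-fold higher number from compound 3 to compound 4 (0.07 log units; within the scatter)). This position on the ring, para to a carboxy group, therefore accepts the longer arm without a fall in the number, and nothing available explains the result.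

As far as these compounds go, the step from compound 3 to compound 4 changes the linker and the ring substituent together, so their separate contributions remain open. A 3-fluorophenyl group on the same ethenyl linker, or an amine on the ring of the arm, would test this position further.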